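The source may report more compounds than this note shows. Statements on the series, on what has been measured and on what is new or still open speak of the compounds shown alone.

Measured in a functional assay on ECa-109 cells (Homo sapiens) for antiproliferative activity, with a stated time of 72 h; on this read-out higher numbers stand for weaker inhibition and lower numbers for stronger inhibition:

- Compound 1 `COc1cc(OC)c(C(=O)/C=C/c2ccccc2Cl)c(O)c1CN1CCCCC1`: 2500 nM
- Compound 2 `COc1cc(OC)c(C(=O)/C=C/c2ccccc2Cl)c(O)c1CN(C)CC(=O)O`: 44400 nM
- Compound 3 `CCN(C)Cc1c(OC)cc(OC)c(C(=O)/C=C/c2ccccc2Cl)c1O`: 1400 nM

Compound 3 sits at the low end of these numbers, level with compound 1: a 1.8-fold lower number from compound 1 to compound 3 (0.25 log units; within the scatter). It stands well clear of the acid-bearing compound, with a 32-fold lower number from compound 2 to compound 3 (1.50 log units; beyond the scatter).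

Compound 4 `COc1cc(OC)c(C(=O)/C=C/c2ccccc2Cl)c(O)c1CN(C)CCCN(C)C` keeps the shared core and extends the amine chain of compound 3: (dimethylamino)methyl in place of hydrogen on a saturated chain carbon, two bonds along the chain from an amine nitrogen. Cut one bond further out, this reads ethyl(methyl)amino to (3-(dimethylamino)propyl)(methyl)amino.

For the measured compounds named here, no measured step adds this group, so the evidence is indirect. The swap of one amine for another, a 1.8-fold lower number from compound 1 to compound 3 (0.25 log units; within the scatter), left the number within the scatter. Going by the values given here, the two large steps, an 18-fold higher number from compound 1 to compound 2 (1.25 log units; beyond the scatter) and a 32-fold lower number from compound 2 to compound 3 (1.50 log units; beyond the scatter), both involve compound 2, the only compound here with a carboxy group, and the entering group has none. With three compounds this is thin support, and none of them carries a second amine nitrogen.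

In this assay the expected change is therefore small, with the estimated step being a 1.3-fold higher number from compound 3 to compound 4 (0.11 log units; within the scatter), and a wide margin remains on either side. Compound 4 is estimated at 1800 nM, with an expected range of 600 nM to 6000 nM.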

Compound 4, half-maximal inhibitory concentration: 3800 nM
Beside the measured number, compound 4's estimate is 2.1-fold (0.32 log units) below it, and the stated range covers the measured number.
By their numbers in this assay, from the lowest: compounds 3, 1 and 4 (each within the scatter of the next, the first and the last beyond it); then compound 2.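

In this assay the entry of (dimethylamino)methyl on a saturated chain carbon, two bonds along the chain from an amine nitrogen, gives a modest step beyond the scatter (a 2.7-fold higher number from compound 3 to compound 4 (0.43 log units; beyond the scatter)), the only such step among these compounds that does not involve compound 2. The same compound remains within the scatter of the piperidin-1-yl compound (a 1.5-fold higher number from compound 1 to compound 4 (0.18 log units; within the scatter)), so the second amine nitrogen and its chain do not set compound 4 apart from compound 1 on this read-out. Against the acid-bearing compound, 2-(dimethylamino)ethyl in place of carboxy still gives a large step (a 12-fold lower number from compound 2 to compound 4 (1.07 log units; beyond the scatter)), so the wide gap between compound 2 and the other compounds holds with this longer diamine chain as well.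

The compounds shown leave open whether a shorter or longer chain ending in dimethylamino, or a ring amine such as morpholine or piperazine at the same place, would follow compound 4 or compound 3 in this assay. Nothing given here accounts for the modest step from the shorter amine chain to the longer one.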